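This account rests on a few compounds, and the source may have more. Where it says the series, first, only, none or still open, it means among the compounds named here.

Compound 1 `CS(=O)(=O)CCCn1c(Cn2nc(S(C)(=O)=O)c3ccncc32)nc2cc(Cl)ccc21`: 2 ug/mL
Compound 2 `CC(C)(O)CCn1c(Cn2nc(S(C)(=O)=O)c3ccncc32)nc2cc(Cl)ccc21`: 41 ug/mL
Compound 3 `CS(=O)(=O)c1nn(Cc2nc3cc(Cl)ccc3n2CCC(O)C(F)(F)F)c2cnccc12`: < 1 ug/mL, a limit of the assay

In a physicochemical assay for solubility, read by spectrophotometry, in phosphate buffer, at pH 6.5 (a lower number here means a less soluble compound, a higher number a more soluble compound), compound 1 gives 2 ug/mL, the lowest of the two numbers shown. Compound 2 gives 41 ug/mL, a rise of a 21-fold higher number from compound 1 to compound 2 (1.31 log units; beyond the scatter). For compound 3 the value < 1 ug/mL is a limit of the assay and not a number (the limit of < 1 ug/mL in this assay, at which 1 of the 3 values shown sits). From compound 1 to compound 3 the step reads an at least 2.0-fold lower number from compound 1 to compound 3 (0.30 log units; that floor lies within the scatter). Compound 4 `CS(=O)(=O)c1nn(Cc2nc3cc(Cl)ccc3n2CC2COC2)c2cnccc12` differs from compound 1 by oxetan-3-yl in place of 2-(methylsulfonyl)ethyl on a saturated chain carbon bound to an aromatic nitrogen. Both measured steps exchange the sulfone-bearing chain for groups carrying a hydroxyl, not for a ring, so neither bears directly on this change, and the expectation stays modest. Compound 4 is expected to give 5 ug/mL, with a range of 1 ug/mL to 25 ug/mL, a step of a 2.5-fold higher number from compound 1 to compound 4 (0.40 log units; beyond the scatter) that may well remain within the scatter.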

Compound 4, solubility: 4 ug/mL
Compound 4: the middle estimate sits 1.3-fold (0.10 log units) above what was measured, and the stated range covers the measured number.
By their numbers in this assay, from the lowest: compounds 1 and 4 (each within the scatter of the next); then compound 2. At a limit, below all of these: compound 3.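

At this position a ring carrying no hydroxyl now stands in place of the 2-(methylsulfonyl)ethyl chain, and in this assay this exchange gives a 2.0-fold higher number from compound 1 to compound 4 (0.30 log units; within the scatter). Set against the 2-hydroxy-2-methylpropyl chain, the same ring gives a 10-fold lower number from compound 2 to compound 4 (1.01 log units; beyond the scatter), and set against the 3,3,3-trifluoro-2-hydroxypropyl chain it gives an at least 4.0-fold higher number from compound 3 to compound 4 (0.60 log units; beyond the scatter). That last step starts from a limit of the assay and not a number: the limit of < 1 ug/mL in this assay, at which 1 of the 4 values shown sits.

The compounds shown leave open how an amine or a carboxylic acid on this chain would read. They also leave open whether a tetrahydropyran ring would read differently from oxetan-3-yl.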